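One aromatic group exchanged on a shared core

The source may report more compounds than this note shows. Statements on the series, on what has been measured and on what is new or still open speak of the compounds shown alone.

Compound 1 `COc1cc(-c2ccnc3cc(-c4ccc(C)cc4)nn23)cc(OC)c1OC` gives 47 nM
Compound 2 `COc1cc(-c2ccnc3cc(-c4ccc5cc[nH]c5c4)nn23)cc(OC)c1OC` gives 23 nM
Compound 3 `COc1cc(-c2ccnc3cc(-c4ccc5ccn(C)c5c4)nn23)cc(OC)c1OC` gives 74 nM

These values come from a functional assay on MCF7 cells (Homo sapiens) for inhibition, read by CCK-8 assay, with a stated time of 48 h (on this read-out higher numbers stand for weaker inhibition and lower numbers for stronger inhibition), and show where compound 3 stands. Its number lies within the scatter of its nearest neighbour (a 1.6-fold higher number from compound 1 to compound 3 (0.20 log units; within the scatter)) but is clearly separated from the lowest number of the three (a 3.2-fold higher number from compound 2 to compound 3 (0.51 log units; beyond the scatter)).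

The unmeasured compound 4 `COc1ccc(-c2cc3nccc(-c4cc(OC)c(OC)c(OC)c4)n3n2)cc1` carries 4-methoxyphenyl in place of 1-methyl-1H-indol-6-yl on an aromatic carbon. The most relevant measured change is the exchange of 4-methylphenyl for 1-methyl-1H-indol-6-yl at that same place, which stayed within the scatter (a 1.6-fold higher number from compound 1 to compound 3 (0.20 log units; within the scatter)). Two modest steps involve 1H-indol-6-yl (a 2.0-fold lower number from compound 1 to compound 2 (0.31 log units; beyond the scatter) and a 3.2-fold higher number from compound 2 to compound 3 (0.51 log units; beyond the scatter)), a group that compound 4 does not contain. Among the measured compounds shown here, no measured pair compares methoxy with methyl directly, so that part of the change remains untested.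

A small fall in the number, no larger than the scatter, is therefore expected in this assay. The expected step is a 1.5-fold lower number from compound 3 to compound 4 (0.17 log units; within the scatter). Compound 4 is estimated at 50 nM (expected range 20 nM to 125 nM).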

Compound 4, half-maximal inhibitory concentration: 125 nM
The estimate for compound 4 lay 2.5-fold (0.40 log units) below the measured number; low and high end bracket the measured number.
By their numbers in this assay, from the lowest: compound 2; then compounds 1, 3 and 4 (each within the scatter of the next, the first and the last beyond it).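

Compound 1 and compound 4 now supply the direct comparison of methoxy with methyl that was missing: in this assay, methoxy in place of methyl on the phenyl group gives a 2.7-fold higher number from compound 1 to compound 4 (0.42 log units; beyond the scatter) and so separates the two. The comparison with the unsubstituted indole is wider, with 4-methoxyphenyl in place of 1H-indol-6-yl giving a 5.4-fold higher number from compound 2 to compound 4 (0.74 log units; beyond the scatter), while the same group in place of 1-methyl-1H-indol-6-yl gives only a 1.7-fold higher number from compound 3 to compound 4 (0.23 log units; within the scatter) and leaves those two groups unresolved. Among the compounds shown here, at this aromatic carbon of the five-membered ring, a small change on the attached aryl group can therefore shift the number beyond the scatter, and compound 2 remains the only compound separated from all the others, though nothing available accounts for these differences.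

Going by these compounds, it remains open whether a hydroxy or dimethylamino group in place of the methoxy, or a carboxylic acid at that spot, would follow the same trend. Equally open, on these data alone, is whether an ethyl group or a longer chain on the indole nitrogen would move the number further than methyl does.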